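Two Methyl Groups Replace Bromo on the Aryl of Compound 4

A few compounds are considered here, and "the series" means these few. Any claim that something is new, unique, unknown or untested is made for them only; others in the source may bear on it.

Within the data shown here, compound 1 `COC1=C(C)C(=O)/C(=C(O)/C=C/c2ccc(Br)cc2)C(=O)C1(C)C` stands at the low end of the three numbers so far obtained in a functional assay on A549 cells (Homo sapiens) for cytotoxicity (a lower number here means that less compound is needed, a higher number that more compound is needed for the effect), giving 1.4 ug/mL. Compound 2 `COC1=C(C)C(=O)/C(=C(O)/C=C/c2cccc(OC)c2)C(=O)C1(C)C` gives 2.8 ug/mL, and compound 3 `COC1=C(C)C(=O)/C(=C(O)/C=C/c2ccc(C)cc2)C(=O)C1(C)C` gives 4.3 ug/mL. The step of a 2.0-fold higher number from compound 1 to compound 2 (0.30 log units; within the scatter) remains within the scatter, whereas a 3.1-fold higher number from compound 1 to compound 3 (0.49 log units; beyond the scatter) lies beyond it, and a 1.5-fold higher number from compound 2 to compound 3 (0.19 log units; within the scatter) is again within the scatter.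

Compound 4 `COC1=C(C)C(=O)/C(=C(O)/C=C/c2c(C)cccc2C)C(=O)C1(C)C` has not yet been tested. It differs from compound 1 in one place: 2,6-dimethylphenyl in place of 4-bromophenyl on a double-bonded chain carbon bound to a double-bonded chain carbon. Two of the measured steps touch the same part of the molecule. The step of a 2.0-fold higher number from compound 1 to compound 2 (0.30 log units; within the scatter) and the step of a 3.1-fold higher number from compound 1 to compound 3 (0.49 log units; beyond the scatter) both exchange the aryl group on that chain carbon, and both move the number upward, the second one beyond the scatter. Since compound 4 likewise loses the bromo and gains methyl groups, the expected outcome is a modest upward move, estimated at a 2.9-fold higher number from compound 1 to compound 4 (0.46 log units; beyond the scatter). For compound 4 the estimated value in this assay is 4 ug/mL, expected to fall between 1.5 ug/mL and 10 ug/mL.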

Compound 4, concentration for half-maximal effect: 8.3 ug/mL
Estimate against measurement, compound 4: 2.1-fold (0.32 log units) below, within the range that was stated.
By their numbers in this assay, from the lowest: compounds 1, 2, 3 and 4 (each within the scatter of the next, the first and the last beyond it).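

Replacing the 4-bromophenyl with 2,6-dimethylphenyl at this place on a double-bonded chain carbon bound to a double-bonded chain carbon gives a 5.9-fold higher number from compound 1 to compound 4 (0.77 log units; beyond the scatter) in this assay and opens the widest span yet seen among these compounds. Among these compounds, the same aryl group also separates compound 4 from the methoxy-bearing aryl, with a 3.0-fold higher number from compound 2 to compound 4 (0.47 log units; beyond the scatter), whereas the earlier compounds placed only compound 3 beyond the scatter of compound 1 and left compound 2 within the scatter of both. Against the 4-methylphenyl of compound 3, however, the result is a 1.9-fold higher number from compound 3 to compound 4 (0.29 log units; within the scatter), so the two methyl-bearing aryl groups cannot be told apart in this assay and both stand beyond the scatter of the bromo compound.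

Because 4-methylphenyl and 2,6-dimethylphenyl differ both in the number of methyl groups and in where those groups sit, the compounds shown cannot separate these two changes. Also open, going by these compounds, is how an aryl group carrying an amine, a carboxylic acid or a longer chain would read at this place in this assay.

No measurement given here explains why the number moves with this exchange.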